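Anilide to ethyl ester at the cinnamoyl carbonyl

The compounds below may be only part of what the source reports. "The series", "measured", "known", "first", "only" and "open" are said of these compounds alone.

Among the measured compounds shown here, compound 1 `COc1cc(/C=C/C(=O)Nc2ccccc2)ccc1OCCCCCCN1CCCCC1` sits in the upper part of the three numbers so far: in a physicochemical assay for lipophilicity, using the shake flask method, measured as octanol-water partition, at pH 7.4 (on this read-out lower numbers stand for lower lipophilicity and higher numbers for higher lipophilicity), compound 1 gives 1.77. Its nearest neighbour is compound 2 `COc1cc(/C=C/C(=O)Nc2ccccc2)ccc1OCCCCCCN1CCCC1`, which in this assay gives 1.76, a step of a number 0.01 log units lower from compound 1 to compound 2 (within the scatter). Compound 3 `COc1cc(/C=C/C(=O)Nc2ccccc2)ccc1OCCCCCCCCCCN1CCCC1` gives 1.86 in this assay, with a number 0.09 log units higher from compound 1 to compound 3 (within the scatter) and a number 0.10 log units higher from compound 2 to compound 3 (within the scatter). All three values lie within the scatter of one another, so no order among them can be read.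

Compound 4 `CCOC(=O)/C=C/c1ccc(OCCCCCCN2CCCCC2)c(OC)c1` differs from compound 1 at the other end of the molecule: ethoxy in place of anilino on a carbonyl carbon. The measured steps all concern the amine at the end of the alkoxy chain; none of them touches the carbonyl end, so none of them bears on this change, and the series gives no direct guide to its size. Those steps only show that the amine variation leaves this assay essentially unchanged.

Compound 4 is therefore expected to move in this assay by a number 0.37 log units lower from compound 1 to compound 4 (beyond the scatter), downward, a step beyond the scatter, resting on the anilide-to-ester exchange alone. The estimate for compound 4 in this assay is 1.4, with a range of 0.9 to 1.9.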

Compound 4, partition coefficient: 1.81
Beside the measured number, compound 4's estimate is 0.41 log units below it; the measured number falls inside the stated range.
By their numbers in this assay, from the lowest: compounds 2, 1, 4 and 3 (each within the scatter of the next).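

In this assay the carbonyl end of the series now has a measured step of its own: ethoxy in place of anilino on a carbonyl carbon gives a number 0.04 log units higher from compound 1 to compound 4 (within the scatter) and so shows no readable difference at this position. This exchange removes a six-membered aromatic ring and the amide hydrogen, and brings in an oxygen, yet that structural difference does not appear as a step beyond the scatter on this read-out. Across the four compounds, every step listed so far, whether at the amine end of the alkoxy chain or at the carbonyl carbon, lies within the scatter, and no compound goes against this, although the data offer no measured basis for explaining the result.

Still open, from the compounds shown here alone, is whether other groups on the same carbonyl carbon, such as a carboxylic acid, a primary amide or a longer butoxy ester, would also remain within the scatter of compound 1 or would give a step beyond it. Also open, going by these compounds, is whether ethoxy in place of anilino gives a similar step when the chain ends in pyrrolidin-1-yl, as in compound 2, rather than in piperidin-1-yl.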